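Removing a Methyl from a Pyridine-Bearing Agonist Scaffold

The source may hold more compounds than are shown below. What is called first, only, known or untested is meant among the compounds shown, and "the series" means these compounds.

Compound 1 `CC(C)N1CCN(c2cccc3c2C[C@H](CN(C)[C@H]2CCCc4cccnc42)NC3)CC1` was tested in a functional assay on CCRF-CEM cells for agonist activity at C-X-C chemokine receptor type 4 (Homo sapiens), read by calcium flux, with a stated time of 25 min; a higher number here means that more compound is needed for the effect, a lower number that less compound is needed. Compound 1 returned only a limit of the assay, > 30000 nM, rather than a number. Compound 2 `Cc1cnc2c(c1)CCC[C@@H]2N(C)C[C@H]1Cc2c(cccc2N2CCNCC2)CN1` likewise gave only a limit in this assay, > 30000 nM. Both results sit at the limit of > 30000 nM in this assay, at which 2 of the 2 values shown sit, so neither compound can be ordered against the other, and compound 2 stands at that limit with no number beneath it. Compound 3 `CN(C[C@H]1Cc2c(cccc2N2CCNCC2)CN1)[C@H]1CCCc2cccnc21` differs from compound 2 by a single change: hydrogen in place of methyl on an aromatic carbon. Going by the values given here, no measured pair shows what this change does, and since both measured compounds sit at the limit, no step beyond the scatter can be read from them. Compound 3 is therefore estimated at 40000 nM (range 10000 nM to 150000 nM). The step this estimate implies, a step that the limit leaves unreadable from compound 2 to compound 3, is expected to lie within the usual scatter, with the result most likely reported again as a limit.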

Compound 3, half-maximal effective concentration: > 30000 nM
Compound 3 was reported as a limit (the forecaster's own chance of this, stated with the estimate: 75%); the middle value is on the limit's open side.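

In this assay compound 3 also gave only a limit, so no step can be read between it and compound 2 or compound 1: the limit of > 30000 nM in this assay, at which 3 of the 3 values shown sit. The compounds shown leave open how far each lies from that limit, and whether either change alters the response.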